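From anilino to (pyridin-3-yl)amino at an assay limit

The source may hold more compounds than are shown below. What is called first, only, known or untested is meant among the compounds shown, and "the series" means these compounds.

In a functional assay on the whole organism with Mus musculus as the target (a higher number here means that more compound is needed for the effect, a lower number that less compound is needed), compound 1 `CCC(=O)Nc1c(C)c(C)c2c(c1C)CC(C)(C)O2` gives only a limit of > 100 mg/kg and no number. Compound 2 `CCOC(=O)Nc1c(C)c(C)c2c(c1C)CC(C)(C)O2` also gives only a limit of > 100 mg/kg and no number. Compound 3 `Cc1c(C)c2c(c(C)c1Nc1ccccc1)CC(C)(C)O2` likewise stands at a limit of > 50 mg/kg and so offers no exact starting point. Compound 4 `Cc1c(C)c2c(c(C)c1Nc1cccnc1)CC(C)(C)O2` carries pyridin-3-yl in place of phenyl on a nitrogen on an aromatic ring. Going by the values given here, two measured steps touch that same nitrogen, (a step that the two limits leave unreadable from compound 1 to compound 3) and (a step that the two limits leave unreadable from compound 2 to compound 3). Neither gives a size that could be carried over. Among the compounds with values here, no measured compound carries pyridin-3-yl, so the data show no direction for this change. The limit of compound 3 at > 50 mg/kg is therefore the only anchor for the expectation. A small step with no firm direction is expected (a step that the limit leaves unreadable from compound 3 to compound 4). Compound 4 is expected near 60 mg/kg within an estimated range from 15 mg/kg to 200 mg/kg and may again give only a limit.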

Compound 4, dose for 50% inhibition: > 50 mg/kg
Compound 4: a limit, no number (the forecaster's own chance of this, stated with the estimate: 60%); the middle value lies beyond the limit too.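

In this assay compound 4 gives only a limit of > 50 mg/kg. Going by these compounds alone, compound 1, compound 2 and compound 3 also give only limits, so no step to compound 4 can be read. From the compounds shown here alone, whether pyridin-3-yl in place of phenyl changes the dose needed, and in which direction, stays open.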